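A few compounds are considered here, and "the series" means these few. Any claim that something is new, unique, unknown or untested is made for them only; others in the source may bear on it.

Of the compounds shown here, two have so far been measured in a functional assay on MCF7 cells (Homo sapiens) for cytotoxicity, read by CCK-8 assay, with a stated time of 24 h; a lower number here means a stronger inhibitor, a higher number a weaker inhibitor. Compound 1 `C=C1CCC(c2csc(/C=C(\C)C(N)=O)c2)CC1` gives 8470 nM, and compound 2 `C/C(=C\c1cc(-c2ccccc2)co1)C(N)=O` gives 3340 nM. Compound 2 holds the lower of the two numbers; its nearest neighbour is compound 1, whose number stands higher by a margin beyond the usual scatter. Compound 3 `C/C(=C\c1cc(-c2ccc(C)cc2)co1)C(N)=O` differs from compound 2 by methyl in place of hydrogen on an aromatic carbon. Within the data shown here, no step between two measured compounds informs this change, so no movement beyond the scatter is expected in either direction. Compound 3 is estimated to give 3000 nM, within 1200 nM to 8000 nM, which means an expected step of a 1.1-fold lower number from compound 2 to compound 3 (0.05 log units; within the scatter) inside the scatter.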

Compound 3, half-maximal inhibitory concentration: 1630 nM
Beside the measured number, compound 3's estimate is 1.8-fold (0.26 log units) above it; the range from low to high includes it.
By their numbers in this assay, from the lowest: compound 3; then compound 2; then compound 1.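

In this assay, methyl in place of hydrogen on an aromatic carbon, para to a large group, gives a 2.0-fold lower number from compound 2 to compound 3 (0.31 log units; beyond the scatter). Among these compounds, this is the first change in a single place that can be read, and it shows that this position of the six-membered aromatic ring responds to one added carbon. Nothing measured here accounts for the step. Going by these compounds, whether chlorine, methoxy, an amine or a longer chain such as ethyl at this place would move the number further remains open, as does methyl on another carbon of that ring.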